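A few compounds are considered here, and "the series" means these few. Any claim that something is new, unique, unknown or untested is made for them only; others in the source may bear on it.

Measured so far:
compound 1 `COc1c(NS(=O)(=O)c2ccc(F)cc2)cc(-c2ccc3nc(NC4CC4)sc3n2)cc1C(N)=O` – 30300 nM
compound 2 `COc1c(NS(=O)(=O)c2ccc(F)cc2)cc(-c2ccn3nc(NC(C)=O)nc3c2)cc1C(N)=O` – "not determined" (no result reported)
compound 3 `COc1c(NS(=O)(=O)c2ccc(F)cc2)cc(-c2ccn3nc(NC(=O)C4CC4)nc3c2)cc1C(N)=O` – "not determined" (no result reported)

Going by the values given here, compound 1 is the only compound with a number in a functional assay on A549 cells (Homo sapiens) for antiproliferative activity, read by MTT assay, with a stated time of 72 h; on this read-out higher numbers stand for weaker inhibition and lower numbers for stronger inhibition; compound 2 and compound 3 carry no result there, so compound 1 cannot be ranked against anything. Its value sits at the weak end of what is usually of interest. Among the compounds with values here, compound 4 `COc1c(NS(=O)(=O)c2ccc(F)cc2)cc(-c2ccc3nc(NC(=O)C4CC4)sc3n2)cc1C(N)=O` differs from compound 1 by cyclopropylcarbonyl in place of cyclopropyl on a nitrogen on an aromatic ring; no measured step of this kind exists in the set, so its size rests on expectation alone. The step of a 1.2-fold higher number from compound 1 to compound 4 (0.06 log units; within the scatter) is expected to stay within the scatter, with no clear direction. Compound 4 is therefore estimated at 35000 nM, between 10000 nM and 120000 nM, with a fair chance that only a limit is reported.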

Compound 4, half-maximal inhibitory concentration: 8050 nM
For compound 4 the middle estimate is 4.3-fold (0.64 log units) above the measured one, outside the stated range (below it).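

In this assay, replacing cyclopropylamino with (cyclopropylcarbonyl)amino gives a 3.8-fold lower number from compound 1 to compound 4 (0.58 log units; beyond the scatter) on the shared core, a modest but readable change. This nitrogen on an aromatic ring is therefore a position where the substituent alters the read-out, and the cyclopropylcarbonyl form is the stronger of this pair. No measurement at hand accounts for the step.

With one pair, the separate contributions of the carbonyl and the cyclopropyl ring cannot be read. Going by these compounds, whether a urea or a longer chain such as pentanoyl at this nitrogen continues the trend remains open, and compound 2 and compound 3 allow no comparison.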